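A few compounds are considered here, and "the series" means these few. Any claim that something is new, unique, unknown or untested is made for them only; others in the source may bear on it.

Measured compounds:
Compound 1 `COc1ccc(OC)c(-c2cc(-c3ccccc3)nn2-c2ccc(S(N)(=O)=O)cc2)c1`: 11900 nM
Compound 2 `Oc1ccc(O)c(-c2cc(-c3ccccc3)nn2-c2ccccc2)c1`: 28500 nM

Of the two compounds measured in a functional assay on cells (Cancer cell lines, Homo sapiens) for cytotoxicity, read by sulforhodamine B assay, with a stated time of 48 h (a higher number here means a weaker inhibitor of growth, a lower number a stronger inhibitor of growth), compound 2 gives the higher number, with compound 1 standing a little lower; the gap between them exceeds the usual scatter, so compound 2 is the weaker of the pair, but the two differ in more than one place, so nothing can be tied to any single group.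

Compound 3 `NS(=O)(=O)c1ccc(-n2nc(-c3ccccc3)cc2-c2cc(O)ccc2O)cc1` is not yet measured. It keeps the dihydroxy-bearing core of compound 2 and differs from it in one place: sulfamoyl in place of hydrogen on an aromatic carbon. Compound 1 carries that same sulfamoyl group, though on a dimethoxy core, so the record offers no isolated reading of this change. A modest fall in the number is expected for compound 3, a 1.9-fold lower number from compound 2 to compound 3 (0.28 log units; within the scatter), mainly because compound 1 gives 11900 nM. Compound 3 is therefore estimated at 15000 nM, within a range of 5000 nM to 45000 nM.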

Compound 3, concentration for 50% growth inhibition: 75700 nM
Compound 3: the middle estimate sits 5.0-fold (0.70 log units) below what was measured, and the stated range ends below it.
By their numbers in this assay, from the lowest: compound 1; then compound 2; then compound 3.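

In this assay the sulfamoyl group now has an isolated reading on the dihydroxy core: sulfamoyl in place of hydrogen on an aromatic carbon, para to a large group, gives a 2.7-fold higher number from compound 2 to compound 3 (0.42 log units; beyond the scatter) and so goes with weaker growth inhibition on this core, a direction compound 1 alone could not reveal. Among the compounds shown here, with the sulfamoyl group held in place, 2,5-dihydroxyphenyl in place of 2,5-dimethoxyphenyl gives a 6.4-fold higher number from compound 1 to compound 3 (0.80 log units; beyond the scatter) and so also weakens growth inhibition, the first single-change reading of that ring's substituents. Nothing available explains either step.

The compounds shown leave open how the sulfamoyl step reads on the 2,5-dimethoxyphenyl core. They also leave open whether a carboxylic acid or an amine at the same place would move the number in the same direction.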